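From compound 2 to compound 3: a changed aryl group

This account rests on a few compounds, and the source may have more. Where it says the series, first, only, none or still open, it means among the compounds named here.

- compound 1 `O=C(N/N=C/c1ccc(F)cc1)Nc1cc2c(Nc3ccc(F)c(Cl)c3)ncnc2cc1O[C@H]1CCOC1` gives "not active" (no number reported)
- compound 2 `O=C(N/N=C/c1ccc(F)cc1Cl)Nc1cc2c(Nc3ccc(F)c(Cl)c3)ncnc2cc1O[C@H]1CCOC1` gives 26100 nM

For the measured compounds named here, in a functional assay on HepG2 cells (Homo sapiens) for cytotoxicity, read by MTT assay, with a stated time of 72 h (on this read-out higher numbers stand for weaker inhibition and lower numbers for stronger inhibition), compound 2 holds the only number, 26100 nM, and the one other measured entry, compound 1, is reported without a number. With a single number, compound 2 cannot be ranked on any scale of values.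

Compound 3 `O=C(N/N=C/c1cccc(Cl)c1Cl)Nc1cc2c(Nc3ccc(F)c(Cl)c3)ncnc2cc1O[C@H]1CCOC1` differs from compound 2 at one place: 2,3-dichlorophenyl in place of 2-chloro-4-fluorophenyl on a carbon with a double bond to nitrogen. There, 2,3-dichlorophenyl stands in place of 2-chloro-4-fluorophenyl on a carbon with a double bond to nitrogen.

Going by the values given here, the data hold no measured step to scale this change in this assay, so no shift beyond the scatter is expected in either direction. The estimated change is a 1.0-fold lower number from compound 2 to compound 3 (0.02 log units; within the scatter), and a report without a number remains possible. Compound 3 is expected at 25000 nM (10000 nM to 60000 nM).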

Compound 3, half-maximal inhibitory concentration: 16900 nM
For compound 3 the middle estimate is 1.5-fold (0.17 log units) above the measured one, and the stated range covers the measured number.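

In this assay, the exchange of 2-chloro-4-fluorophenyl for 2,3-dichlorophenyl on a carbon with a double bond to nitrogen gives a 1.5-fold lower number from compound 2 to compound 3 (0.19 log units; within the scatter), so the two compounds cannot be told apart on this read-out. For the compounds shown here, this is the first step with a number at both ends, and it shows that these two aryl groups, each with 8 heavy atoms, read alike here. The data shown offer no measured property that bears on this result.

From the compounds shown here alone, it remains open whether a group of another kind at this place, such as a pyridine ring or a phenyl ring carrying a carboxylic acid or an amine, would move the number beyond the scatter. Also open, going by these compounds, is how far compound 1, reported as "not active" (no number reported), stands from these two values.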